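The source may hold more compounds than are shown below. What is called first, only, known or untested is meant among the compounds shown, and "the series" means these compounds.

Among the measured compounds shown here, in a functional assay on A549 cells (Homo sapiens) for cytotoxicity, read by MTT assay, with a stated time of 72 h (a lower number here means a stronger inhibitor, a higher number a weaker inhibitor), the three measured members spread widely. Compound 2 `O=C(Nc1ccc(Oc2ccnc3[nH]ccc23)c(F)c1)c1nccc(-c2cccc(Cl)c2)n1` gives 450 nM, compound 3 `O=C(Nc1ccc(Oc2ccnc3[nH]ccc23)c(F)c1)c1nccc(-c2ccc([N+](=O)[O-])cc2)n1` gives 4470 nM, and compound 1 `COc1ccc(-c2ccnc(C(=O)Nc3ccc(Oc4ccnc5[nH]ccc45)cc3)n2)cc1` gives 13300 nM. Compound 3 thus stands second highest of the three numbers, with compound 1 as its nearest neighbour and compound 2 as its furthest. For the measured compounds named here, the only single-point step available is a 9.9-fold higher number from compound 2 to compound 3 (1.00 log units; beyond the scatter), which shows that the aryl substituent alone can move this assay well beyond the scatter.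

Compound 4 `COc1ccc(-c2ccnc(C(=O)Nc3ccc(Oc4ccnc5[nH]ccc45)c(F)c3)n2)cc1` is the next member to be measured. It differs from compound 3 by methoxy in place of nitro on an aromatic carbon. Going by the values given here, no measured pair isolates this change: compound 1 and compound 3 carry the same two aryl groups but also differ in a fluorine, which compound 4 carries and compound 1 lacks, so their two values show only that the methoxyphenyl member without fluorine lies above the nitrophenyl member with it. Nothing measured bears on the fluorine by itself.

Weighing the value of compound 1 against that of compound 3, the expected step is a 2.0-fold higher number from compound 3 to compound 4 (0.30 log units; within the scatter), upward in number. Compound 4 is accordingly estimated at 9000 nM in this assay, within a range of 3000 nM to 30000 nM.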

Compound 4, half-maximal inhibitory concentration: 5430 nM
Compound 4: middle estimate off by 1.7-fold (0.22 log units), on the high side; the range from low to high includes it.
By their numbers in this assay, from the lowest: compound 2; then compounds 3 and 4 (each within the scatter of the next); then compound 1.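

In this assay, methoxy in place of nitro gives a 1.2-fold higher number from compound 3 to compound 4 (0.08 log units; within the scatter) and so leaves the two groups unseparated at this position on the ring, while a 12-fold higher number from compound 2 to compound 4 (1.08 log units; beyond the scatter) sets 4-methoxyphenyl well apart from 3-chlorophenyl, as 4-nitrophenyl already was. Compound 4 also gives the fluorine its first single-change pair: fluoro in place of hydrogen yields a 2.4-fold lower number from compound 1 to compound 4 (0.39 log units; beyond the scatter) and lies beyond the scatter, a reading that holds only for the 4-methoxyphenyl members. No measurement at hand accounts for any of these steps.

Among the fluorine-bearing members, the shift seen so far goes with the change from 3-chlorophenyl to either of the two 4-substituted phenyl groups, but whether it follows the chlorine or its place on the ring stays open, and a 4-chlorophenyl member would separate the two. Also open, on these data alone, are how an amine or a carboxylic acid would read in place of nitro and methoxy on this ring, and whether the fluoro step carries over to the 3-chlorophenyl and 4-nitrophenyl members.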